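The compounds below may be only part of what the source reports. "The series", "measured", "known", "first", "only" and "open" are said of these compounds alone.

Compound 1 `CC(C)=CCC1Cc2c(OCCCNC(=O)c3ccco3)cc(=O)n(CCCO)c2CC1(C)C`: 4.3%
Compound 2 `CC(C)=CCC1Cc2c(OCCCNC(=O)c3cccs3)cc(=O)n(CCCO)c2CC1(C)C`: 5.6%

In a functional assay on PANC-1 cells (Homo sapiens) for inhibition, read by MTT assay, with a stated time of 24 h, tested at 10 uM (a higher number here means more inhibition at the concentration tested (going by the name of the read-out), a lower number less inhibition), both measured compounds show little inhibition, and compound 2 stands beside compound 1 with a gap that the step of a number 1.3 percentage points higher from compound 1 to compound 2 (within the scatter) shows to lie within the scatter. Compound 3 `CC(C)=CCC1Cc2c(OCCCNC(=O)c3ccc([N+](=O)[O-])cc3)cc(=O)n(CCCO)c2CC1(C)C` carries the change (4-nitrophenyl in place of thiophen-2-yl on a carbonyl carbon). Going by the values given here, the only step that bears on an exchange at this carbonyl carbon is a number 1.3 percentage points higher from compound 1 to compound 2 (within the scatter), and it was within the scatter, so the step of a number 1.4 percentage points higher from compound 2 to compound 3 (within the scatter) is expected to stay within the scatter as well. Compound 3 is therefore estimated at 7%, in a range from 0% to 20%.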

Compound 3, a percentage reported as inhibition, at one concentration (the size of the read-out at that concentration, not a potency): 9.1%
Compound 3: middle estimate off by 2.1 percentage points, on the low side, and the stated range covers the measured number.
By their numbers in this assay, from the lowest: compounds 1, 2 and 3 (each within the scatter of the next).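

In this assay, 4-nitrophenyl on this carbonyl carbon gives a number 3.5 percentage points higher from compound 2 to compound 3 (within the scatter) against thiophen-2-yl and a number 4.8 percentage points higher from compound 1 to compound 3 (within the scatter) against furan-2-yl, so even a six-membered aromatic ring with more heavy atoms leaves the number within the scatter of both five-membered rings. All three groups on this carbonyl carbon therefore give similar, low inhibition. Nothing measured explains this result. Still open, as far as these compounds go, is whether a group of a different kind here, such as an aminomethyl group, a carboxylic acid or a longer alkyl chain, would move the number beyond the scatter.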